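Methylating the amide nitrogen of a pyrrolidinyl benzamide

The source may hold more compounds than are shown below. What is called first, only, known or untested is meant among the compounds shown, and "the series" means these compounds.

Of the compounds shown here, three have been measured in a functional assay on the whole organism with Rattus norvegicus as the target; on this read-out lower numbers stand for an effect already at smaller amounts and higher numbers for an effect only at larger amounts of compound. Compound 1, `CNc1cc(OC)c(C(=O)NCCN(C)Cc2ccccc2)cc1Cl`, gives 0.21 mg/kg, and compound 2, `COc1cc(N(C)C)c(Cl)cc1C(=O)NCCN(C)Cc1ccccc1`, gives 0.54 mg/kg; the change methyl in place of hydrogen on a nitrogen on an aromatic ring produced a 2.6-fold higher number from compound 1 to compound 2 (0.41 log units; beyond the scatter). Compound 3, `COc1cc(NC(C)=O)c(Cl)cc1C(=O)NC1CCN(Cc2ccccc2)C1`, gives 1.8 mg/kg. The difference between the core of compound 3 and that of compound 1 is not broken down here. Compound 4, `COc1cc(N(C)C(C)=O)c(Cl)cc1C(=O)NC1CCN(Cc2ccccc2)C1`, carries the change (methyl in place of hydrogen on an amide-type nitrogen); this is the same kind of change as in compound 2, but the place differs, an amide-type nitrogen whose other neighbours are aromatic carbon and carbonyl carbon rather than a nitrogen on an aromatic ring whose other neighbours are aromatic carbon and saturated chain carbon. Because of a 2.6-fold higher number from compound 1 to compound 2 (0.41 log units; beyond the scatter), a step of a 2.1-fold higher number from compound 3 to compound 4 (0.32 log units; beyond the scatter) is expected for compound 4. Compound 4 is therefore estimated at 3.8 mg/kg, between 1.6 mg/kg and 9 mg/kg.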

Compound 4, dose for half-maximal effect: > 30 mg/kg
Compound 4 was reported as a limit; the forecaster's own chance of this, stated with the estimate: 10%; at least 7.8-fold (0.89 log units) between middle value and limit.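

In this assay compound 4 gives > 30 mg/kg, which is a limit of the assay and not a number. Methyl in place of hydrogen on an amide-type nitrogen brought an at least 16-fold higher number from compound 3 to compound 4 (1.22 log units; beyond the scatter), and the change did not carry over from one core to the other at one size: the same change on two cores in this assay, a 2.6-fold higher number (0.41 log units; beyond the scatter) from compound 1 to compound 2 and an at least 16-fold higher number (1.22 log units; beyond the scatter) from compound 3 to compound 4, at least 6.4-fold (0.81 log units) apart, beyond the scatter of two such steps This shows that the size of the step on the first pair could not be relied on for the second, but not how large the second step really is, nor whether the kind of nitrogen or the rest of the core sets the gap, as the two pairs differ in both.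

The compounds shown leave open whether acetamido to acetyl(methyl)amino brings a step of similar size on the core of compound 1. They also leave open how an ethyl on the same amide-type nitrogen would compare with the methyl.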